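Changing the Amide Cap: From Fluorophenyl to Nitrophenyl

The source may hold more compounds than are shown below. What is called first, only, known or untested is meant among the compounds shown, and "the series" means these compounds.

Compound 3 `CN1CCC(c2c[nH]c3ccc(NC(=O)c4cccc(F)c4)nc23)CC1` stands second highest of three numbers in an assay for binding affinity to 5-hydroxytryptamine receptor 1F (Homo sapiens), read by radioligand binding (on this read-out lower numbers stand for stronger inhibition and higher numbers for weaker inhibition), where compound 3 gives 11 nM. For comparison, compound 1 `CN1CCC(c2c[nH]c3ccc(NC(=O)C4CC4)nc23)CC1` gives 9.8 nM, and compound 2 `COc1ccccc1C(=O)Nc1ccc2[nH]cc(C3CCN(C)CC3)c2n1` gives 20 nM. Two earlier steps exchange the group on the carbonyl carbon just as the new step does: a 1.1-fold higher number from compound 1 to compound 3 (0.05 log units; within the scatter) and a 1.8-fold lower number from compound 2 to compound 3 (0.26 log units; within the scatter), both within the scatter, while only a 2.0-fold higher number from compound 1 to compound 2 (0.31 log units; beyond the scatter) edges beyond it. Compound 4 `CN1CCC(c2c[nH]c3ccc(NC(=O)c4ccc([N+](=O)[O-])cc4)nc23)CC1` carries 4-nitrophenyl in place of 3-fluorophenyl on a carbonyl carbon. Because a 1.1-fold higher number from compound 1 to compound 3 (0.05 log units; within the scatter) and a 1.8-fold lower number from compound 2 to compound 3 (0.26 log units; within the scatter) barely moved the number, the expected step of a 1.3-fold higher number from compound 3 to compound 4 (0.10 log units; within the scatter) for compound 4 is small, with no clear direction. Compound 4 is therefore estimated at 14 nM, within a likely range from 5 nM to 40 nM.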

Compound 4, inhibition constant: 7.7 nM
Compound 4: the middle estimate sits 1.8-fold (0.26 log units) above what was measured, within the range that was stated.
By their numbers in this assay, from the lowest: compounds 4, 1, 3 and 2 (each within the scatter of the next, the first and the last beyond it).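

The 4-nitrophenyl group has more heavy atoms than 3-fluorophenyl or cyclopropyl and adds hydrogen-bond acceptors, yet in this assay the number stays within the scatter on both comparisons: a 1.4-fold lower number from compound 3 to compound 4 (0.15 log units; within the scatter) and a 1.3-fold lower number from compound 1 to compound 4 (0.10 log units; within the scatter). Only the comparison with the 2-methoxyphenyl amide passes the scatter, and modestly: a 2.6-fold lower number from compound 2 to compound 4 (0.41 log units; beyond the scatter). Nothing available explains these differences.

Still open, going by these compounds, is how this place on the carbonyl carbon responds to a longer alkyl chain, an amine or a carboxylic acid. Also open, on these data alone, is whether 3-nitrophenyl would match 4-nitrophenyl.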